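The source may report more compounds than this note shows. Statements on the series, on what has been measured and on what is new or still open speak of the compounds shown alone.

Measured so far:
compound 1, `COc1cc2c(cc1OC)C(CC(N)=O)CC2`, in a functional assay on the whole organism (strain Wistar) for inhibition, with Rattus norvegicus as the target, read by paw edema, with stated times of 60 min and 6 h, at a dose of 100 mg/kg by the oral route; a lower number here means less inhibition, a higher number more inhibition at the dose given (going by the name of the read-out): 27.8%
compound 2, `COc1cc2c(cc1OC)C(CC(=O)N(C)C)CC2`, in this assay: 33.3%

On these two numbers compound 2 has the highest value; its nearest neighbour is compound 1, and the step of a number 5.5 percentage points higher from compound 1 to compound 2 (within the scatter) lies within the scatter, so the two are not separated by the data. The account now follows the step from compound 2 to compound 3, `CCN(CC)C(=O)CC1CCc2cc(OC)c(OC)cc21`. The change is diethylamino in place of dimethylamino on a carbonyl carbon. Among the compounds with values here, the only measured step that bears on it is a number 5.5 percentage points higher from compound 1 to compound 2 (within the scatter), which also replaced the group on the carbonyl carbon and stayed within the scatter. Within the data shown here, nothing in the measurements points to a direction for the further change, and the one comparable step gave no movement beyond the scatter, so the expected step of a number 0.3 percentage points lower from compound 2 to compound 3 (within the scatter) is one of no change beyond the scatter. The estimate for compound 3 in this assay is therefore 33%, with a range from 18% to 48%, pending the measurement.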

Compound 3, a percentage reported as inhibition, in the whole organism at one dose (the size of the read-out at that dose, not a potency): 31.5%
Beside the measured number, compound 3's estimate is 1.5 percentage points above it; the measured number falls inside the stated range.
By their numbers in this assay, from the lowest: compounds 1, 3 and 2 (each within the scatter of the next).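

In this assay, diethylamino in place of dimethylamino on a carbonyl carbon gives a number 1.8 percentage points lower from compound 2 to compound 3 (within the scatter), so this position has now taken a second replacement without a change that the read-out can separate. The full replacement of amino by diethylamino gives a number 3.7 percentage points higher from compound 1 to compound 3 (within the scatter), which shows that even the two ends of this short series, 3 heavy atoms of dimethylamino aside, stay within the scatter of each other, and that amino, dimethylamino and diethylamino on this carbonyl carbon are not told apart by the paw swelling numbers at this one dose. The data offer no explanation for why these replacements leave the number where it is.

Going by these compounds, whether the same holds for a cyclic amine such as piperidine or morpholine on the carbonyl carbon, or for a carboxylic acid or an ester in place of the amide, stays open. Also open, on these data alone, is whether a longer chain on the nitrogen, such as dibutylamino, would move the number beyond the scatter.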